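The source may hold more compounds than are shown below. What is called first, only, known or untested is meant among the compounds shown, and "the series" means these compounds.

Working notes on the series

Compound 1 `CC1C(=O)N(CCCCCCOc2ccc(Cl)cc2)/C(=N\C#N)N1c1ccncc1` is the reference point of this set. In a functional assay on HepG2 cells (Homo sapiens) for cytotoxicity (a higher number here means a weaker inhibitor, a lower number a stronger inhibitor), compound 1 gives 282 nM. Compound 2 `CC1C(=O)N(CCCCCCCOc2ccc(Cl)cc2)/C(=N\C#N)N1c1ccncc1` carries the change (4-chlorophenoxy)methyl in place of 4-chlorophenoxy on a saturated chain carbon, six bonds along the chain from an amide-type nitrogen in a ring relative to compound 1, and in this assay compound 2 gives 359 nM. The step is a 1.3-fold higher number from compound 1 to compound 2 (0.10 log units; within the scatter), so the longer chain leaves the number essentially where it was.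

Compound 3 `N#C/N=C1\N(CCCCCCOc2ccc(Cl)cc2)C(=O)C(c2ccccc2)N1c1ccncc1` differs from compound 1 by phenyl in place of methyl on a saturated ring carbon, and this is how the two cores differ. In this assay compound 3 gives 44 nM, which is a 6.4-fold lower number from compound 1 to compound 3 (0.81 log units; beyond the scatter). Compound 3 has the lowest number of the three measured compounds, with its steps to compound 1 and to compound 2 both beyond the scatter.

Compound 4 `N#C/N=C1\N(CCCCCCCOc2ccc(Cl)cc2)C(=O)C(c2ccccc2)N1c1ccncc1` has not been measured. It relates to compound 3 by (4-chlorophenoxy)methyl in place of 4-chlorophenoxy on a saturated chain carbon, six bonds along the chain from an amide-type nitrogen in a ring, and the place of this change is the same, word for word, as the place of the change from compound 1 to compound 2. For the measured compounds named here, that same change is the only one in this set that is measured twice in sense, and its only measured instance is a 1.3-fold higher number from compound 1 to compound 2 (0.10 log units; within the scatter).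

Compound 4 is expected to sit at about a 1.3-fold higher number from compound 3 to compound 4 (0.10 log units; within the scatter) from compound 3, because the same change read a 1.3-fold higher number from compound 1 to compound 2 (0.10 log units; within the scatter) on the core of compound 1, a step within the scatter. This expectation rests on a single pair, so it is thin. Compound 4 is estimated at 55 nM in this assay, with a range of 28 nM to 110 nM.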

Compound 4, half-maximal inhibitory concentration: 380 nM
The estimate for compound 4 lay 6.9-fold (0.84 log units) below the measured number; the whole stated range lies below it.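

In this assay, (4-chlorophenoxy)methyl in place of 4-chlorophenoxy does not carry over from the core of compound 1 to the core of compound 3, where the step is an 8.6-fold higher number from compound 3 to compound 4 (0.94 log units; beyond the scatter) and the two readings differ: the same change on two cores in this assay, a 1.3-fold higher number (0.10 log units; within the scatter) from compound 1 to compound 2 and an 8.6-fold higher number (0.94 log units; beyond the scatter) from compound 3 to compound 4, 6.8-fold (0.83 log units) apart, beyond the scatter of two such steps. Read the other way, phenyl in place of methyl on the saturated ring carbon gives a 1.1-fold higher number from compound 2 to compound 4 (0.02 log units; within the scatter) on the longer chain, so the lower number seen with compound 3 does not reappear there: the same change on two cores in this assay, a 6.4-fold lower number (0.81 log units; beyond the scatter) from compound 1 to compound 3 and a 1.1-fold higher number (0.02 log units; within the scatter) from compound 2 to compound 4, 6.8-fold (0.83 log units) apart, beyond the scatter of two such steps. The two changes therefore do not add up in this set, and compound 3 stands apart from compound 1, compound 2 and compound 4, but this rests on a single square of four compounds and does not show why the steps differ or whether the same holds for any other pair of cores.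

The compounds shown leave open whether the low number of compound 3 is confined to one chain length or also appears with a shorter chain or with a chain longer than that of compound 4. They also leave open how an ethyl or a benzyl group on the saturated ring carbon would read on either chain.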